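Fluoro on the pyridine of compound 1: expected effect

The source may hold more compounds than are shown below. What is called first, only, known or untested is meant among the compounds shown, and "the series" means these compounds.

Measured compounds:
compound 1, `CCN(c1ccc(C#N)c(Cl)c1)c1cc(-c2cccnc2)ccc1C`: 2000 nM
compound 2, `N#Cc1ccc(N2CCCc3c(-c4ccncc4)cccc32)cc1C(F)(F)F`: 15000 nM
compound 3, `N#Cc1ccc(N2CCc3cc(-c4cncnc4)ccc3C2)cc1C(F)(F)F`: "not determined" (no result reported)

The read-out is a functional assay on CWR22R cells (Homo sapiens) for antiproliferative activity, read by CCK-8 assay, with a stated time of 6 days; a higher number here means a weaker inhibitor, a lower number a stronger inhibitor. Compound 1 gives 2000 nM in this assay and has the lowest number of the two that carry a number. Compound 2 gives 15000 nM in this assay; the gap from compound 1 to compound 2 is beyond the scatter, but compound 2 differs from compound 1 in several places at once, so nothing about any single change can be taken from that pair. Compound 3, `N#Cc1ccc(N2CCc3cc(-c4cncnc4)ccc3C2)cc1C(F)(F)F`, gives "not determined" (no result reported) in this assay, so it carries no number here.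

Compound 4 is `CCN(c1ccc(C#N)c(Cl)c1)c1cc(-c2ccc(F)nc2)ccc1C`. It differs from compound 1 in one place: fluoro in place of hydrogen on an aromatic carbon. Among the compounds with values here, no measured pair shows this change on its own, so the step has to be judged without a direct precedent.

A single fluoro on an aromatic carbon is a small change, and the expected step from compound 1 to compound 4, a 1.3-fold lower number from compound 1 to compound 4 (0.12 log units; within the scatter), is expected to stay within the scatter. Compound 4 is therefore expected to give about 1500 nM in this assay, with a range from 600 nM to 4000 nM.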

Compound 4, half-maximal inhibitory concentration: 16500 nM
Estimate against measurement, compound 4: 11-fold (1.04 log units) below, outside the stated range (above it).
By their numbers in this assay, from the lowest: compound 1; then compounds 2 and 4 (each within the scatter of the next).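

In this assay, within the data shown here, pyridin-3-yl to 6-fluoropyridin-3-yl is the first change that can be read on its own, and it gives an 8.3-fold higher number from compound 1 to compound 4 (0.92 log units; beyond the scatter) for a single added fluorine atom. The earlier compounds shown here could not show this, as compound 2 differs from compound 1 in several places at once and compound 3 carries no number; the step now shows that the aromatic carbon next to the ring nitrogen, para to a large group, does not tolerate every small replacement of hydrogen in this cell read-out. No measurement is available that bears on what lies behind the step.

Still open, as far as these compounds go, is whether this rise in the number belongs to fluoro in particular or to any group on this carbon, which a methyl, a methoxy or an amine in the same place would help to separate. Also open, from the compounds shown here alone, is whether fluoro on another carbon of the pyridine ring would give a step of similar size, or whether the effect is confined to this one position.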